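The compounds below may be only part of what the source reports. "The series", "measured", "known", "first", "only" and "open" are said of these compounds alone.

Of the compounds shown here, three sharing one core have been tested so far, and a fourth is about to join them. Compound 1 `COc1ccc(Br)cc1Nc1cc(NC(=O)Nc2c(Cl)cccc2Cl)ncn1` gives 45% in a functional assay on NCI-H520 cells (Homo sapiens) for inhibition, read by MTT assay, with a stated time of 48 h, tested at 10 uM; a lower number here means less inhibition, a higher number more inhibition at the concentration tested (going by the name of the read-out). Compound 2 `Cc1ccc(Nc2cc(NC(=O)Nc3c(Cl)cccc3Cl)ncn2)cc1F` gives 33.5% in this assay, and compound 3 `CC(C)(C)c1cccc(Nc2cc(NC(=O)Nc3c(Cl)cccc3Cl)ncn2)c1` gives 29.6%. Compound 2 therefore stands second highest of the three numbers: its gap to compound 3 lies within the scatter, while compound 1 sits clearly above it, as the step of a number 11.5 percentage points lower from compound 1 to compound 2 (beyond the scatter) shows, a modest but real fall when one aromatic group on the nitrogen is exchanged for another.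

Compound 4 `Cc1cc(F)cc(Nc2cc(NC(=O)Nc3c(Cl)cccc3Cl)ncn2)c1` differs from compound 2 only in where the methyl sits on that outer ring: 3-fluoro-5-methylphenyl in place of 3-fluoro-4-methylphenyl on a nitrogen on an aromatic ring. The two compounds are built from the same atoms, joined differently. Among the compounds with values here, no measured step covers such a rearrangement; the only step available, from compound 1 to compound 2, swaps a whole group and so speaks only loosely to it. With nothing pointing in either direction, the expected change in this assay from compound 2 to compound 4 is a number 1.5 percentage points lower from compound 2 to compound 4 (within the scatter), which is to say none beyond the scatter. Compound 4 is thus estimated at 32% in this assay, with a plausible range from 20% to 45%.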

Compound 4, a percentage reported as inhibition, at one concentration (the size of the read-out at that concentration, not a potency): 60.5%
Estimate against measurement, compound 4: 28.5 percentage points below; measured number above the stated range.
By their numbers in this assay, from the lowest: compounds 3 and 2 (each within the scatter of the next); then compound 1; then compound 4.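

Moving a single methyl on the outer ring, with 3-fluoro-5-methylphenyl in place of 3-fluoro-4-methylphenyl on a nitrogen on an aromatic ring, gives a number 27 percentage points higher from compound 2 to compound 4 (beyond the scatter) in this assay and so shows that the arrangement of this ring matters here, even when its atoms stay the same. The earlier comparison involved the exchange of a whole group, whereas this pair separates arrangement from composition, and the number with the new group is also higher than with the 5-bromo-2-methoxyphenyl group, giving a number 15.5 percentage points higher from compound 1 to compound 4 (beyond the scatter) on that exchange. Nothing available here explains why this rearrangement changes the read-out so strongly.

The compounds shown cover only two arrangements of the fluorine and methyl pair, so it remains open whether the higher number would survive replacing the methyl of 3-fluoro-5-methylphenyl with a chlorine, a trifluoromethyl or a methoxy group, or adding an amine or a carboxylic acid to the outer ring. On these data alone, each number also comes from a single concentration, so how these compounds would compare in potency across a range of concentrations remains unknown.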